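Biphenyl ester replacing a phenylpropyl ester in a dihydropyridine series

The source may report more compounds than this note shows. Statements on the series, on what has been measured and on what is new or still open speak of the compounds shown alone.

Measured compounds:
- compound 1 `COC(=O)C1=C(C)NC(C)=C(C(=O)OCc2cc([N+](=O)[O-])cc([N+](=O)[O-])c2)C1c1cccc([N+](=O)[O-])c1`: 40 nM
- compound 2 `COC(=O)C1=C(C)NC(C)=C(C(=O)OCCC(C)c2ccccc2)C1c1cccc([N+](=O)[O-])c1`: 11 nM

Both were tested in a functional assay on HEK293 cells for antagonist activity at Voltage-dependent L-type calcium channel subunit alpha-1D (Rattus norvegicus), read by FLIPR; a higher number here means a weaker inhibitor, a lower number a stronger inhibitor. Compound 2 holds the lowest of the two numbers; its nearest neighbour is compound 1, and the shift a 3.6-fold lower number from compound 1 to compound 2 (0.56 log units; beyond the scatter) takes the series from the 3,5-dinitrophenyl ester to the 2-phenylpropyl ester. Compound 3 `COC(=O)C1=C(C)NC(C)=C(C(=O)OCc2ccc(-c3ccccc3)cc2)C1c1cccc([N+](=O)[O-])c1` has not been measured. It differs from compound 2 by 4-phenylphenyl in place of 2-phenylpropyl on a saturated chain carbon bound to an oxygen next to a carbonyl group. For the measured compounds named here, the only step that bears on this change is the one from compound 1 to compound 2, which was modest and beyond the scatter; it links an aromatic ring on the chain carbon to a longer chain carrying the ring, and compound 3 returns to an aromatic ring on that carbon, now a 4-phenylphenyl group. Going by the values given here, no measured step tests a second aromatic ring there. Compound 3 is therefore expected to sit somewhat above compound 2, an estimated step of a 2.3-fold higher number from compound 2 to compound 3 (0.36 log units; beyond the scatter) in this assay, giving an estimate of 25 nM with a range from 8 nM to 80 nM.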

Compound 3, half-maximal inhibitory concentration: 74 nM
Estimate against measurement, compound 3: 3.0-fold (0.47 log units) below; the measured number falls inside the stated range.
By their numbers in this assay, from the lowest: compound 2; then compounds 1 and 3 (each within the scatter of the next).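

In this assay, replacing the 2-phenylpropyl ester with the 4-phenylphenyl group loses what compound 2 had gained (a 6.7-fold higher number from compound 2 to compound 3 (0.83 log units; beyond the scatter)), so a second aromatic ring on the saturated chain carbon does not reproduce the low number of compound 2. Set against the 3,5-dinitrophenyl ester, the change lies within the scatter (a 1.9-fold higher number from compound 1 to compound 3 (0.27 log units; within the scatter)), so these two groups cannot be told apart here, and only the 2-phenylpropyl group, the one without an aromatic ring directly on that carbon, stands apart. Nothing available accounts for this difference.

Going by these compounds, it remains open whether the low number of compound 2 follows from the chain, its branching methyl or the ring itself, which an unbranched 3-phenylpropyl ester and a plain benzyl ester could separate. On these data alone, how a chain ending in an amine would behave at this place is also open.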